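The source may report more compounds than this note shows. Statements on the series, on what has been measured and on what is new or still open speak of the compounds shown alone.

Compound 1 `COc1ccc2ncc(S(=O)(=O)c3ccc(C)c(Cl)c3)c(N3CCC(C)CC3)c2c1` was examined in an assay on isolated protein for displacement of a labelled ligand from metabotropic glutamate receptor 5 (Homo sapiens), with a stated time of 60 min, tested at 1 uM (a higher number here means more inhibition at the concentration tested (going by the name of the read-out), a lower number less inhibition), where compound 1 gives 85%. Compound 2 `COc1ccc2ncc(S(=O)(=O)c3cccc(C#N)c3)c(N3CCC(C)CC3)c2c1` differs from it by 3-cyanophenyl in place of 3-chloro-4-methylphenyl on a sulfonyl sulfur, and in this assay compound 2 gives 90%; the step is a number 5 percentage points higher from compound 1 to compound 2 (within the scatter). Compound 3 `Cc1ccc(S(=O)(=O)c2cnc3ccc(F)cc3c2N2CCC(C)CC2)cc1Cl` carries a different core, differing from compound 1 by fluoro in place of methoxy on an aromatic carbon; in this assay compound 3 gives 91%, and the step is a number 6 percentage points higher from compound 1 to compound 3 (within the scatter). Compound 4 `CC1CCN(c2c(S(=O)(=O)c3cccc(C#N)c3)cnc3ccc(F)cc23)CC1` has not yet been measured. Among the measured compounds shown here, it differs from compound 3 by 3-cyanophenyl in place of 3-chloro-4-methylphenyl on a sulfonyl sulfur, which is the same change as the one made from compound 1 to compound 2, since the two places are described in the same words. On the core of compound 3, that change is expected to give a number 1 percentage points higher from compound 3 to compound 4 (within the scatter), an expectation that rests on the step of a number 5 percentage points higher from compound 1 to compound 2 (within the scatter), which stayed within the scatter, and on compound 3 already giving 91%, which leaves little room upward. Compound 4 is therefore estimated at 92%, with a likely range from 85% to 98%.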

Compound 4, a percentage reported as inhibition, at one concentration (the size of the read-out at that concentration, not a potency): 93%
Compound 4: middle estimate off by 1 percentage points, on the low side; the range from low to high includes it.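

In this assay, 3-cyanophenyl in place of 3-chloro-4-methylphenyl on a sulfonyl sulfur gives a number 2 percentage points higher from compound 3 to compound 4 (within the scatter), and this step agrees with its counterpart on the other core: the same change on two cores in this assay, a number 5 percentage points higher (within the scatter) from compound 1 to compound 2 and a number 2 percentage points higher (within the scatter) from compound 3 to compound 4, 3 percentage points apart, within the scatter of two such steps. Fluoro in place of methoxy on an aromatic carbon gives a number 3 percentage points higher from compound 2 to compound 4 (within the scatter), and this step also agrees with its counterpart: the same change on two cores in this assay, a number 6 percentage points higher (within the scatter) from compound 1 to compound 3 and a number 3 percentage points higher (within the scatter) from compound 2 to compound 4, 3 percentage points apart, within the scatter of two such steps. Within this set, each change therefore carries from one core to the other without a detectable difference, but every step lies within the scatter and the read-out reflects one concentration rather than a potency, so this does not show that either change alters the result, or that their effects truly add up.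

The compounds shown leave open how a group of another kind on the sulfonyl sulfur, such as a carboxylic acid-bearing phenyl or a longer alkyl chain, would behave. They also leave open whether these two changes would still carry across cores where the numbers stand lower and a step has more room to show.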